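The source may hold more compounds than are shown below. What is called first, only, known or untested is meant among the compounds shown, and "the series" means these compounds.

Compound 2, `O=[N+]([O-])c1c(CS(=O)(=O)c2ccccc2)nc2c(C#Cc3ccc(CO)cc3)cc(Cl)cn12`, differs from compound 1, `O=[N+]([O-])c1c(CS(=O)(=O)c2ccccc2)nc2c(C#Cc3ccccc3)cc(Cl)cn12`, only by hydroxymethyl in place of hydrogen on an aromatic carbon. In an ADME assay on HepG2 cells (Homo sapiens) for cytotoxicity, read by MTT assay, with a stated time of 72 h (a lower number here means that less compound is tolerated, a higher number that more compound is tolerated), compound 1 gives only a limit of the assay, > 3900 nM. Compound 2 likewise reaches only a limit in this assay, > 15600 nM. The step that the two limits leave unreadable from compound 1 to compound 2 therefore cannot be read in size or direction, because the limit of > 3900 nM in this assay, at which 1 of the 2 values shown sits, and the limit of > 15600 nM in this assay, at which 1 of the 2 values shown sits, are both edges of what the assay reports rather than measured numbers. Compound 2 thus stands at a limit, with no number of its own, and the two compounds shown cannot be ordered against each other.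

Compound 3, `CC(C)(O)C#Cc1cc(Cl)cn2c([N+](=O)[O-])c(CS(=O)(=O)c3ccccc3)nc12`, carries 1-hydroxy-1-methylethyl in place of 4-(hydroxymethyl)phenyl on a triple-bonded carbon. No measured step bears directly on this change; the single step shown is itself unreadable, so nothing in the data points to a rise or a fall beyond the scatter. Compound 3 is therefore expected to sit near compound 2, with an expected step that the limit leaves unreadable from compound 2 to compound 3 of no readable size, and most likely to be reported once more as a limit. The estimate for compound 3 is 20000 nM, expected to fall between 8000 nM and 60000 nM.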

Compound 3, half-maximal cytotoxic concentration: > 62500 nM
Compound 3 was reported as a limit; the forecaster's own chance of this, stated with the estimate: 80%; middle value at least 3.1-fold (0.49 log units) from the limit.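

Compound 3 also reaches only a limit in this assay, > 62500 nM. Its steps from compound 1 and from compound 2, which also stand at limits, cannot be read in size or direction. The compounds shown leave open the concentration at which any of the three becomes cytotoxic, and whether changing the group on the triple-bonded carbon shifts it at all.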